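The compounds below may be only part of what the source reports. "The series", "measured", "known", "first", "only" and "open" are said of these compounds alone.

Compound 1, `CC(C)CNC(=O)n1c(=O)oc2ccc(C3CCN(C)CC3)cc21`, compound 2, `CC(C)N1CCC(c2ccc3c(c2)oc(=O)n3C(=O)NCCCCc2ccccc2)CC1`, and compound 3, `O=C(NCCCCc1ccccc1)n1c2c(oc1=O)CCNC2`, were run in an ADME assay on a cell-free system (plasma, Mus musculus) for metabolic stability, read by LC-MS, tested at 2 uM; a higher number here means that the compound lasts longer, a lower number that the compound disappears faster. In this assay compound 1 gives 0.5 h, and compound 2 gives 0.667 h. Of the two plain numbers, compound 2 has the larger, but its gap to compound 1 lies within the usual scatter, so the two cannot be told apart. Compound 3 reaches the limit of this assay, > 2 h, which is a limit of the measurement and not a number, as noted in the limit of > 2 h in this assay, at which 1 of the 3 values shown sits.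

Compound 4, `CCN1CCC(c2ccc3c(c2)oc(=O)n3C(=O)NCCCCc2ccccc2)CC1`, has not yet been run in this assay. It differs from compound 2 in one place: hydrogen in place of methyl on a saturated chain carbon bound to an amine nitrogen in a ring and a saturated chain carbon. Seen one bond further out, the isopropyl becomes an ethyl, so the 1-isopropylpiperidin-4-yl becomes a 1-ethylpiperidin-4-yl.

For the measured compounds named here, no step between measured compounds of this kind is available to guide the size of the change. For compound 4 the expected step is a 1.1-fold lower number from compound 2 to compound 4 (0.05 log units; within the scatter), that is, no change beyond the scatter in either direction. Compound 4 is therefore estimated at 0.6 h, with a likely range from 0.3 h to 1.2 h.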

Compound 4, half-life: 0.833 h
Estimate against measurement, compound 4: 1.4-fold (0.14 log units) below, and the stated range covers the measured number.
By their numbers in this assay, from the lowest: compounds 1, 2 and 4 (each within the scatter of the next). At a limit, above all of these: compound 3.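

Going from the 1-isopropylpiperidin-4-yl to the 1-ethylpiperidin-4-yl gives the only single-place step so far in this assay, a 1.2-fold higher number from compound 2 to compound 4 (0.10 log units; within the scatter), so taking away this one methyl does not shift the half-life beyond what repeat measurements would show. For the compounds shown here, no pair among the earlier compounds differed in just one place, so this position had no direct reading before. Nothing measured here accounts for this result or ties any property of the two groups to it.

Left open is whether a longer chain such as butyl, or a carboxylic acid carried on the ethyl, would also stay within the scatter at this place in this assay. Going by these compounds, it is equally open whether the same swap from isopropyl to ethyl would read alike in a compound with a different 4-phenylbutyl replacement, such as a cyclohexyl group.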